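Trifluoromethyl in place of methyl: compound 3 to compound 4

The compounds below may be only part of what the source reports. "The series", "measured", "known", "first", "only" and "open" are said of these compounds alone.

Three compounds of the series carry a measurement in a functional assay on HeLa cells (Homo sapiens) for cytotoxicity, read by CCK-8 assay, with a stated time of 24 h; a lower number here means a stronger inhibitor, a higher number a weaker inhibitor. Going by the values given here, compound 1 `C/C(=C\c1cc(-c2ccccc2)co1)C(N)=O` gives 3280 nM and is the only one with a number. Compound 2 `C/C(=C\c1cc(C2=CCCCC2)co1)C(N)=O` gives > 50000 nM, which is a limit of the assay rather than a number. Compound 3 `C/C(=C\c1cc(-c2ccc(C)cc2)cs1)C(N)=O` likewise gives > 50000 nM, again a limit of the assay and not a number. Among the compounds with values here, compound 3 thus stands at the limit of > 50000 nM in this assay, at which 2 of the 3 values shown sit, with no measured value from which a step could be counted; no pair of measured compounds differing in one place is available in this assay.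

Compound 4 `C/C(=C\c1cc(-c2ccc(C(F)(F)F)cc2)cs1)C(N)=O` differs from compound 3 in one place: trifluoromethyl in place of methyl on an aromatic carbon, para to a large group. Within the data shown here, nothing measured bears on this exchange; the numbers say only that compound 1 returns a number in this assay while compound 2 and compound 3 return a limit.

With compound 3 at the limit, no change beyond the scatter is expected in this assay. The step expected is an at least 1.1-fold lower number from compound 3 to compound 4 (0.04 log units; that floor lies within the scatter), taken as none beyond the scatter. Compound 4 is therefore estimated at 45000 nM, within 10000 nM to 150000 nM, with a substantial chance that this assay again reports only a limit.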

Compound 4, half-maximal inhibitory concentration: > 50000 nM
Compound 4: a limit, no number (the forecaster's own chance of this, stated with the estimate: 70%); at least 1.1-fold (0.04 log units) between middle value and limit.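

Compound 3 and compound 4 both stop at a limit of the assay rather than a number, so no step can be read between them: the limit of > 50000 nM in this assay, at which 3 of the 4 values shown sit.

The compounds shown leave open whether trifluoromethyl in place of methyl on an aromatic carbon changes the read-out at all in this assay, in either direction.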